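Thiophene to Isoquinoline on an Acylated Lipid Amide

A few compounds are considered here, and "the series" means these few. Any claim that something is new, unique, unknown or untested is made for them only; others in the source may bear on it.

Among the measured compounds shown here, compound 2 `CCCCCCCCCCCCCCCCCCNC(=O)[C@@H](NC(=O)c1cccs1)[C@@H](C)O` stands within the scatter of the only other number gathered so far: in a functional assay on MCF7 cells (Homo sapiens) for cytotoxicity, read by MTT assay, with a stated time of 48 h (on this read-out lower numbers stand for stronger inhibition and higher numbers for weaker inhibition), compound 2 gives 25700 nM, while compound 1 `CCCCCCCCCCCCCCCCCCNC(=O)[C@@H](N)[C@@H](C)O` gives 27400 nM. For the measured compounds named here, the single measured step, a 1.1-fold lower number from compound 1 to compound 2 (0.03 log units; within the scatter), shows that acylating the amine nitrogen with an aromatic group left the read-out essentially where it was. Compound 3 `CCCCCCCCCCCCCCCCCCNC(=O)[C@@H](NC(=O)c1nccc2ccccc12)[C@@H](C)O` carries the change (isoquinolin-1-yl in place of thiophen-2-yl on a carbonyl carbon). Going by the values given here, no measured step swaps one aromatic acyl group for another, so only the step between compound 1 and compound 2 bears on the question, and it speaks for a small effect at most. A slight move towards a lower number is expected, but nothing that should clear the scatter, an estimated 1.3-fold lower number from compound 2 to compound 3 (0.11 log units; within the scatter). Compound 3 is therefore expected to give about 20000 nM in this assay, with a range from 8000 nM to 50000 nM.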

Compound 3, half-maximal inhibitory concentration: 30800 nM
The estimate for compound 3 lay 1.5-fold (0.19 log units) below the measured number, within the range that was stated.
By their numbers in this assay, from the lowest: compounds 2, 1 and 3 (each within the scatter of the next).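

In this assay, replacing the five-membered aromatic ring of thiophen-2-yl with the two six-membered aromatic rings of isoquinolin-1-yl, on a carbonyl carbon whose other neighbour is an amide-type nitrogen, gives a 1.2-fold higher number from compound 2 to compound 3 (0.08 log units; within the scatter) and so does not shift the read-out. Measured against the unacylated amine, the (isoquinolin-1-yl)carbonyl group gives a 1.1-fold higher number from compound 1 to compound 3 (0.05 log units; within the scatter), which makes it a second aromatic acyl group on this nitrogen that stays within the scatter. No available evidence accounts for this lack of response.

The compounds shown leave open whether an acyl group carrying an amine or a carboxylic acid would move the number at this nitrogen. Among the compounds shown here, they also leave open what a shorter alkyl chain would do in place of the one all three compounds share.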